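A few compounds are considered here, and "the series" means these few. Any claim that something is new, unique, unknown or untested is made for them only; others in the source may bear on it.

Measured compounds in a functional assay on Capan-2 cells (Homo sapiens) for inhibition, read by MTT assay, with a stated time of 72 h; a lower number here means a stronger inhibitor of growth, a higher number a weaker inhibitor of growth:
compound 1 `CC(C)(C)c1ccc(CNCCCNS(=O)(=O)c2cc(C(F)(F)F)cc(C(F)(F)F)c2)cc1` gives 2100 nM
compound 2 `O=S(=O)(NCCCNCc1ccc(Cl)c(Cl)c1)c1cc(C(F)(F)F)cc(C(F)(F)F)c1` gives 1800 nM
compound 3 `O=S(=O)(NCCCNCc1ccc(Cl)c(C(F)(F)F)c1)c1cc(C(F)(F)F)cc(C(F)(F)F)c1` gives 9100 nM

Compound 3 has the highest number of the three: a 4.3-fold higher number from compound 1 to compound 3 (0.64 log units; beyond the scatter), and a 5.1-fold higher number from compound 2 to compound 3 (0.70 log units; beyond the scatter), while a 1.2-fold lower number from compound 1 to compound 2 (0.07 log units; within the scatter). Compound 4 `O=S(=O)(NCCCNCC1COc2ccccc2O1)c1cc(C(F)(F)F)cc(C(F)(F)F)c1` is not yet measured; it differs from compound 3 in one place: 2,3-dihydro-1,4-benzodioxin-2-yl in place of 4-chloro-3-(trifluoromethyl)phenyl on a saturated chain carbon bound to an amine nitrogen. Within the data shown here, the steps that bear on this are the two exchanges of the group on that same chain carbon, both modest in size and both ending at compound 3. Among the measured compounds shown here, no measured step brings in the entering group, so the direction rests only on compound 3 sitting at the high end. A modest lower number is expected for compound 4, estimated as a 2.6-fold lower number from compound 3 to compound 4 (0.41 log units; beyond the scatter). The estimate for compound 4 in this assay is 3500 nM, range 900 nM to 14000 nM.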

Compound 4, concentration for 50% growth inhibition: 2500 nM
Compound 4: the middle estimate sits 1.4-fold (0.15 log units) above what was measured, within the range that was stated.
By their numbers in this assay, from the lowest: compounds 2, 1 and 4 (each within the scatter of the next); then compound 3.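

The earlier compounds shown here carried only substituted phenyl groups on the saturated chain carbon bound to an amine nitrogen; in this assay, 2,3-dihydro-1,4-benzodioxin-2-yl shows that a group with a non-aromatic ring and hydrogen-bond acceptors can stand there, with a 3.6-fold lower number from compound 3 to compound 4 (0.56 log units; beyond the scatter) as its step. With a 1.4-fold higher number from compound 2 to compound 4 (0.14 log units; within the scatter) and a 1.2-fold higher number from compound 1 to compound 4 (0.08 log units; within the scatter), only 4-chloro-3-(trifluoromethyl)phenyl stands apart among the four groups. No evidence on hand accounts for this.

Open, going by these compounds, is how a carboxylic acid or a primary amine on this chain carbon would read, and whether a longer chain in the shared core would alter these numbers.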